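This account rests on a few compounds, and the source may have more. Where it says the series, first, only, none or still open, it means among the compounds named here.

Compound 2 `Nc1nc(N2CCN(C(=O)C3CCCCC3)CC2)c2cc(F)sc2n1` is tested in a functional assay on cells (Lymphocyte); a lower number here means a stronger inhibitor, a higher number a weaker inhibitor. For compound 2 this assay gives only a limit, > 10000 nM, not a number. Compound 1 `Nc1nc(N2CCN(C(=O)CCc3ccccc3)CC2)c2cc(F)sc2n1` carries phenethyl where compound 2 carries cyclohexyl; in this assay compound 1 gives 6990 nM. The step of an at least 1.4-fold higher number from compound 1 to compound 2 (0.15 log units; that floor lies within the scatter) is therefore known only as a floor set by the limit of > 10000 nM in this assay, at which 1 of the 2 values shown sits. Compound 3 `Nc1nc(N2CCN(C(=O)c3cccnc3)CC2)c2cc(F)sc2n1` has not yet been measured; it differs from compound 2 by pyridin-3-yl in place of cyclohexyl on a carbonyl carbon. Within the data shown here, no measured step exchanges cyclohexyl for pyridin-3-yl, so the only guide is that compound 2 sits at the limit of this assay and compound 1 sits close to that limit. A step of a number no higher from compound 2 to compound 3 (the limit leaves the size open) is therefore expected, meaning no change beyond the scatter. Compound 3 is estimated at 10000 nM, with a range from 3000 nM to 30000 nM, and a fair chance that this assay again reports only a limit.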

Compound 3, half-maximal inhibitory concentration: > 10000 nM
Compound 3 ended at the assay's limit; the forecaster's own chance of this, stated with the estimate: 55%; the middle value lies on the limit itself.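

In this assay compound 3 gives > 10000 nM, which is a limit and not a number. Placing pyridin-3-yl on the carbonyl carbon, and with it a ring nitrogen and a hydrogen-bond acceptor that cyclohexyl lacks, therefore gives no readable value in this assay. The comparison with phenethyl gives an at least 1.4-fold higher number from compound 1 to compound 3 (0.15 log units; that floor lies within the scatter), a floor that does not separate the two compounds, while the step between compound 2 and compound 3 cannot be read, and the picture at this position remains coarse: the limit of > 10000 nM in this assay, at which 2 of the 3 values shown sit.

Still open, from the compounds shown here alone, is whether any other group on this carbonyl carbon, such as a small methyl, an amine or a longer chain ending in a carboxylic acid, would give a value clearly under the limit. Also open, going by these compounds, is how far the true values of compound 2 and compound 3 lie beyond that limit.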